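The compounds below may be only part of what the source reports. "The series", "measured", "known", "first", "only" and "open" are said of these compounds alone.

Of the compounds shown here, three from one series have been tested in a functional assay on NCI-H460 cells (Homo sapiens) for inhibition, read by sulforhodamine B assay, with a stated time of 48 h; on this read-out higher numbers stand for weaker inhibition of growth and lower numbers for stronger inhibition of growth. Compound 1, `CCOC(=O)C1=C(C)NC(=O)NC1c1ccc(SC)cc1`, gives 3.6 ug/mL in this assay. Compound 3, `CCOC(=O)C1=C(C)NC(=S)NC1c1ccc(SC)cc1`, gives 21.6 ug/mL, and compound 2, `CCCc1ccc(C2NC(=S)NC(C)=C2C(=O)OCC)cc1`, gives 22.5 ug/mL. Compound 1 and compound 3 share much of their structure, but the difference between the two cores is not broken down here; their two values show that compound 1 carries the lowest number of the three, and both gaps to it lie beyond the scatter.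

Compound 3 and compound 2 differ in one place only: propyl in place of methylsulfanyl on an aromatic carbon. That change produced a 1.0-fold higher number from compound 3 to compound 2 (0.02 log units; within the scatter), so the number stayed essentially where it was.

Compound 4, `CCCc1ccc(C2NC(=O)NC(C)=C2C(=O)OCC)cc1`, has not yet been measured. It arises from compound 1 by the same change at the same place: propyl in place of methylsulfanyl on an aromatic carbon. Because the earlier step of a 1.0-fold higher number from compound 3 to compound 2 (0.02 log units; within the scatter) was flat, compound 4 is expected to show a step of a 1.1-fold higher number from compound 1 to compound 4 (0.02 log units; within the scatter). The estimate for compound 4 in this assay is therefore 3.8 ug/mL, with a likely range from 1.8 ug/mL to 8 ug/mL.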

Compound 4, concentration for 50% growth inhibition: 49.7 ug/mL
Beside the measured number, compound 4's estimate is 13-fold (1.12 log units) below it; measured number outside the range, above it.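

In this assay, propyl in place of methylsulfanyl gave a 14-fold higher number from compound 1 to compound 4 (1.14 log units; beyond the scatter), a large loss of growth inhibition. The identical change on the other core had left the number essentially where it stood, so a step seen on one core did not carry over to the other: the same change on two cores in this assay, a 1.0-fold higher number (0.02 log units; within the scatter) from compound 3 to compound 2 and a 14-fold higher number (1.14 log units; beyond the scatter) from compound 1 to compound 4, 13-fold (1.12 log units) apart, beyond the scatter of two such steps. Within the data shown here, with only one pair on each core, this shows that the two cores answer differently to this change, but not why they do, nor how any further core would answer.

The compounds shown leave open whether other carbon chains at this place, such as ethyl or the longer butyl, would follow the large step seen on the core of compound 1 or the flat result seen on the core of compound 3. An amine or a carboxylic acid on the same aromatic carbon would show whether the gap between the two cores also holds for groups quite unlike methylsulfanyl and propyl.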